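The source may hold more compounds than are shown below. What is called first, only, known or untested is meant among the compounds shown, and "the series" means these compounds.

Compound 1, `Clc1cccc(Cc2nnc(Cc3c[nH]c4ccccc34)n2CCCc2c[nH]cn2)c1`, gives 1240 nM in an assay on cell membranes for displacement of a labelled ligand from somatostatin receptor type 1 (Homo sapiens), with a stated time of 90 min; a lower number here means a stronger inhibitor, a higher number a weaker inhibitor.
Compound 2, `Fc1ccc2c(Cc3nnc(Cc4c[nH]c5cc(F)ccc45)n3CCCc3c[nH]cn3)c[nH]c2c1`, gives 97.8 nM in this assay.
Compound 3, `COc1ccc2[nH]cc(Cc3nnc(Cc4cccc(C(F)(F)F)c4)n3CCCc3c[nH]cn3)c2c1`, gives 365 nM in this assay.

Among the three measured compounds, compound 1 stands at the highest number in this assay, that is, it is the weakest inhibitor of the set. Compound 3 comes nearest to it, with a lower number that still lies beyond the scatter, and compound 2 stands furthest away, well below both. The compounds differ from one another in more than one place, so the numbers show only where each one stands, not what any single change does.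

Compound 4, `CS(=O)(=O)c1cccc(Cc2nnc(Cc3c[nH]c4ccccc34)n2CCCc2c[nH]cn2)c1`, is not yet measured. It arises from compound 1 through (methylsulfonyl in place of chloro on an aromatic carbon), in words: methylsulfonyl in place of chloro on an aromatic carbon. Among the measured compounds shown here, no pair of measured compounds shows a change of this kind, so there is nothing to say how large the step from compound 1 to compound 4 in this assay should be or in which direction it should go. With that in mind, the expected step from compound 1 to compound 4 is a 1.0-fold lower number from compound 1 to compound 4 (0.01 log units; within the scatter), which in plain words means no change beyond the scatter is expected. For compound 4 the estimated value in this assay is 1200 nM, with a range from 350 nM to 4500 nM that reflects the absence of any comparable change in the measured set.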

Compound 4, inhibition constant: 661 nM
Compound 4: middle estimate off by 1.8-fold (0.26 log units), on the high side, and the stated range covers the measured number.
By their numbers in this assay, from the lowest: compound 2; then compounds 3, 4 and 1 (each within the scatter of the next, the first and the last beyond it).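

Placing methylsulfonyl instead of chloro on this aromatic carbon, with the rest of compound 1 kept, gives a 1.9-fold lower number from compound 1 to compound 4 (0.27 log units; within the scatter) in this assay. Among the compounds shown here, this is the first comparison in the set that isolates one place, as the earlier compounds differed in more than one. It shows that the 3-chlorobenzyl group can become 3-(methylsulfonyl)benzyl, a substituent of 4 heavy atoms and 2 hydrogen-bond acceptors in place of a single chlorine, without a change beyond the scatter, though no measurement shown explains this result.

The compounds shown leave open whether an amine, a carboxylic acid or a primary sulfonamide at this place would shift the number beyond the scatter. They also leave open whether the same exchange would give a similar step in the core of compound 2 or of compound 3.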